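A few compounds are considered here, and "the series" means these few. Any claim that something is new, unique, unknown or untested is made for them only; others in the source may bear on it.

Compound 2 `CC(C)OC(=O)CNC(=O)C(CSc1ccc([N+](=O)[O-])cc1[N+](=O)[O-])NC(=O)CCC(NC(=O)OCc1ccccc1)C(=O)O` gives the lowest of the three numbers in a physicochemical assay for lipophilicity (on this read-out lower numbers stand for lower lipophilicity and higher numbers for higher lipophilicity), at 2.23. Compound 1 `CCCOC(=O)CNC(=O)C(CSc1ccc([N+](=O)[O-])cc1[N+](=O)[O-])NC(=O)CCC(NC(=O)OCc1ccccc1)C(=O)O` gives 2.31, and compound 3 `CCCC(C)OC(=O)CNC(=O)C(CSc1ccc([N+](=O)[O-])cc1[N+](=O)[O-])NC(=O)CCC(NC(=O)OCc1ccccc1)C(=O)O` gives 2.8. The steps among them are a number 0.08 log units lower from compound 1 to compound 2 (within the scatter), a number 0.49 log units higher from compound 1 to compound 3 (beyond the scatter) and a number 0.57 log units higher from compound 2 to compound 3 (beyond the scatter). Compound 4 `CC(C)OC(=O)CNC(=O)C(CSc1ccc([N+](=O)[O-])cc1[N+](=O)[O-])NC(=O)CCC(NC(=O)OCc1ccccc1)C(=O)OC(C)C` differs from compound 2 in one place: isopropyl in place of hydrogen on an oxygen next to a carbonyl group. Within the data shown here, no measured step adds a group at this oxygen, so the steps that bear on it are only those that enter carbons elsewhere, above all a number 0.57 log units higher from compound 2 to compound 3 (beyond the scatter), which entered an ethyl group; compound 4 enters an isopropyl group. An upward step in this assay of comparable or larger size is therefore expected, a number 1.07 log units higher from compound 2 to compound 4 (beyond the scatter). Compound 4 is expected to give 3.3, between 2.7 and 4.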

Compound 4, partition coefficient: 3.93
The estimate for compound 4 lay 0.63 log units below the measured number; low and high end bracket the measured number.
By their numbers in this assay, from the lowest: compounds 2 and 1 (each within the scatter of the next); then compound 3; then compound 4.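

At this oxygen, the change from carboxy to isopropoxycarbonyl gives a number 1.70 log units higher from compound 2 to compound 4 (beyond the scatter) in this assay, the first step shown at this position. Among these compounds, this is a larger move than the one from the ethyl change elsewhere on the molecule, which gave a number 0.57 log units higher from compound 2 to compound 3 (beyond the scatter). Nothing shown accounts for the size of the step.

The compounds shown leave open whether a methyl group or a longer chain on this oxygen would give a step of similar size. They also leave open how an amide would read at this position.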